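Swapping the Aryl Group on a Fused Core

The source may hold more compounds than are shown below. What is called first, only, known or untested is meant among the compounds shown, and "the series" means these compounds.

Compound 1 `Fc1ccc(-c2cc3c(cn2)ncn3-c2ccc(OC(F)F)cc2)c(Cl)c1` carries a 2-chloro-4-fluorophenyl group on its shared core. In a functional assay on HL-60 cells (Homo sapiens) for activation, read by flow cytometry, with a stated time of 4 days (a lower number here means that less compound is needed, a higher number that more compound is needed for the effect), compound 1 gives 90 nM, the lowest of the two numbers seen so far. Compound 2 `CC(C)Oc1cc(F)ccc1-c1cc2c(cn1)ncn2-c1ccc(OC(F)F)cc1` keeps the core but has an isopropoxy in place of chloro on an aromatic carbon; in this assay compound 2 gives 1100 nM. That difference is a 12-fold higher number from compound 1 to compound 2 (1.09 log units; beyond the scatter), a large loss from a single change within the 2-chloro-4-fluorophenyl group. Compound 3 `Cc1cc(O)ccc1-c1cc2c(cn1)ncn2-c1ccc(OC(F)F)cc1` has not yet been measured. It differs from compound 1 as follows: 4-hydroxy-2-methylphenyl in place of 2-chloro-4-fluorophenyl on an aromatic carbon. Within the data shown here, the one measured step bears on this only indirectly, since it altered the same group but with a different substituent, so a smaller loss than that seen with compound 2 is expected. For compound 3 the expected step is a 2.8-fold higher number from compound 1 to compound 3 (0.44 log units; beyond the scatter), giving an estimate of 250 nM, with a range from 80 nM to 900 nM.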

Compound 3, half-maximal effective concentration: 890 nM
Compound 3: the middle estimate sits 3.6-fold (0.55 log units) below what was measured; the range from low to high includes it.
By their numbers in this assay, from the lowest: compound 1; then compounds 3 and 2 (each within the scatter of the next).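

In this assay, among these compounds, the change to 4-hydroxy-2-methylphenyl gives a 9.9-fold higher number from compound 1 to compound 3 (1.00 log units; beyond the scatter), so a second replacement at this position also loses ground, and this time the chloro is not the only part of the group that changes. The 2-chloro-4-fluorophenyl group of compound 1 therefore still gives the lowest number of the three, yet compound 3 swaps the chloro for a methyl and the fluoro for a hydroxy at once, so the step cannot be assigned to either swap alone. No measurement shown here explains the loss.

A phenyl group pairing the methyl with the fluoro, or the chloro with the hydroxy, would separate the two swaps. On these data alone, how an amine in place of the hydroxy would compare also remains open.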